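This account rests on a few compounds, and the source may have more. Where it says the series, first, only, none or still open, it means among the compounds named here.

Of the compounds shown here, three sharing one core have been measured in a functional assay on HCC827 cells (Homo sapiens) for antiproliferative activity, read by MTT assay, with a stated time of 72 h; on this read-out lower numbers stand for stronger inhibition and higher numbers for weaker inhibition. Compound 1, `CN1CCN(c2ccc(Nc3ncc4nc(Nc5ccc(F)cc5)n(CCNS(=O)(=O)C5CC5)c4n3)cc2)CC1`, gives 50 nM. Compound 2, `CN1CCN(c2ccc(Nc3ncc4nc(Nc5ccc(F)cc5)n([C@@H]5CCN(C(=O)OC(C)(C)C)C5)c4n3)cc2)CC1`, gives 27 nM, and the step of a 1.9-fold lower number from compound 1 to compound 2 (0.27 log units; within the scatter) is small. Compound 3, `CNC(=O)CN1CC[C@H](n2c(Nc3ccc(F)cc3)nc3cnc(Nc4ccc(N5CCN(C)CC5)cc4)nc32)C1`, gives 1520 nM, the highest of the three numbers; it sits a 30-fold higher number from compound 1 to compound 3 (1.48 log units; beyond the scatter) and a 56-fold higher number from compound 2 to compound 3 (1.75 log units; beyond the scatter), both large steps beyond the scatter.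

Compound 4, `CN1CCN(c2ccc(Nc3ncc4nc(Nc5ccc(F)cc5)n([C@H]5CCN(C(=O)OC(C)(C)C)C5)c4n3)cc2)CC1`, has not yet been measured. It differs from compound 3 in a single place: tert-butoxycarbonyl in place of (methylcarbamoyl)methyl on an amine nitrogen in a ring. The step from compound 2 to compound 3 covers the same pair of groups in the opposite direction, and it was large, a 56-fold higher number from compound 2 to compound 3 (1.75 log units; beyond the scatter). The step from compound 1 to compound 3, which also replaced a small group with the (methylcarbamoyl)methyl-bearing pyrrolidinyl, was likewise large. Reversing that change is therefore expected to bring the number down strongly, by roughly the size of the earlier step, so that compound 4 should land close to the numbers of compound 1 and compound 2.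

On this basis compound 4 is expected to give about 40 nM in this assay, with a likely range from 12 nM to 130 nM, which means an expected step of a 38-fold lower number from compound 3 to compound 4 (1.58 log units; beyond the scatter).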

Compound 4, half-maximal inhibitory concentration: 580 nM
Compound 4: the middle estimate sits 15-fold (1.16 log units) below what was measured; the whole stated range lies below it.
By their numbers in this assay, from the lowest: compounds 2 and 1 (each within the scatter of the next); then compound 4; then compound 3.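

Compound 4 separates two changes that were combined in the comparison of compound 2 with compound 3. The large step of a 21-fold higher number from compound 2 to compound 4 (1.33 log units; beyond the scatter) can be assigned to the stereocentre at the saturated ring carbon alone, because nothing else separates the pair: the fact that compounds 2 and 4 differ only in the configuration as drawn. With the configuration held as in compound 4, exchanging the group on the ring nitrogen gives only the modest step of a 2.6-fold lower number from compound 3 to compound 4 (0.42 log units; beyond the scatter), and the tert-butoxycarbonyl group does not restore the number seen with the 2-((cyclopropylsulfonyl)amino)ethyl group, as the step of a 12-fold higher number from compound 1 to compound 4 (1.06 log units; beyond the scatter) shows.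

The compounds shown leave open how the (methylcarbamoyl)methyl group behaves in the configuration drawn for compound 2, so it cannot be told how much of the large gap between compound 2 and compound 3 belongs to the group and how much to the stereocentre. They also leave open what a small acetyl group, or a free amine with only hydrogen on that ring nitrogen, would give in either configuration.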